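Changing the amine chain on compound 1

The source may hold more compounds than are shown below. What is called first, only, known or untested is meant among the compounds shown, and "the series" means these compounds.

For the measured compounds named here, in a functional assay on HepG2 cells (Homo sapiens) for antiproliferative activity, read by MTT assay, with a stated time of 48 h (a lower number here means a stronger inhibitor, a higher number a weaker inhibitor), compound 1 `COc1cc2oc(-c3ccccc3)cc(=O)c2c(O)c1OCCCCN1CCN(C)CC1` gives 36700 nM, the higher of the two numbers measured so far. Compound 2 `CN1CCN(CCCCOc2c(OCc3ccccc3)cc3oc(-c4ccccc4)cc(=O)c3c2O)CC1` gives 2500 nM. Going by the values given here, the one measured step is a 15-fold lower number from compound 1 to compound 2 (1.17 log units; beyond the scatter), a large change beyond the usual scatter, made by placing phenyl in place of hydrogen on a saturated chain carbon bound to an oxygen on an aromatic ring.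

Compound 3 `CCN(CC)CCCOc1c(OC)cc2oc(-c3ccccc3)cc(=O)c2c1O` differs from compound 1 elsewhere: diethylamino in place of (4-methylpiperazin-1-yl)methyl on a saturated chain carbon, three bonds along the chain from an oxygen on an aromatic ring. Put simply, diethylamino stands in place of (4-methylpiperazin-1-yl)methyl on a saturated chain carbon, three bonds along the chain from an oxygen on an aromatic ring.

Among the compounds with values here, the measured step concerns a different group, so its size does not carry over, and no measurement yet tests this chain change. The expectation therefore rests on compound 1 at 36700 nM, with no step beyond the scatter expected in this assay. The estimated change is a 1.2-fold lower number from compound 1 to compound 3 (0.09 log units; within the scatter), although a real shift in either direction remains possible. For compound 3 the expected value is 30000 nM, with an estimated range of 11000 nM to 85000 nM.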

Compound 3, half-maximal inhibitory concentration: 3700 nM
Compound 3: middle estimate off by 8.1-fold (0.91 log units), on the high side, and the stated range ends above it.
By their numbers in this assay, from the lowest: compounds 2 and 3 (each within the scatter of the next); then compound 1.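

Replacing (4-methylpiperazin-1-yl)methyl with diethylamino on a saturated chain carbon, three bonds along the chain from an oxygen on an aromatic ring, gives a 9.9-fold lower number from compound 1 to compound 3 (1.00 log units; beyond the scatter) in this assay, so the far end of this chain is a place where a change can move the number beyond the scatter. The change is more than a swap of one amine for another: the entering group has 5 heavy atoms and no ring, the leaving group has 8 heavy atoms and a six-membered ring, and the same difference can also be read as 3-(4-methylpiperazin-1-yl)propyl to 2-(diethylamino)ethyl. Nothing measured on these compounds explains why the number falls.

The amine and the chain length change together in this step, so a diethylamino group on a longer chain, or a 4-methylpiperazin-1-yl group on a shorter one, would be needed to tell their contributions apart. Other amines at the chain end, such as morpholine or piperidine, remain open, as does whether the phenyl change seen on compound 1 would add to this one.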